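The source may hold more compounds than are shown below. What is called first, only, known or untested is meant among the compounds shown, and "the series" means these compounds.

Three close relatives share one core and were all tested in a functional assay on Ehrlich cells (Mus musculus) for cytotoxicity, read by MTT assay, with a stated time of 48 h; a lower number here means a stronger inhibitor, a higher number a weaker inhibitor. Compound 1 `Cc1ccc(-c2csc(NC(=O)COc3ccc(Cl)c(C)c3)n2)cc1` gives 58800 nM. Compound 2 `Cc1ccc(-c2csc(NC(=O)COc3ccccc3C)n2)cc1` gives 54400 nM, which places it second highest of the three numbers, with compound 1 nearest and compound 3 furthest. Compound 3 `Cc1ccccc1OCC(=O)Nc1nc(-c2ccc(Br)cc2)cs1` gives 44900 nM. The two steps that join them are small: a 1.1-fold lower number from compound 1 to compound 2 (0.03 log units; within the scatter), and a 1.2-fold lower number from compound 2 to compound 3 (0.08 log units; within the scatter); neither rises above the scatter of repeated measurements.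

Compound 4 `Cc1ccc(OCC(=O)Nc2nc(-c3ccc(C)cc3)cs2)cc1` has not yet been measured in this assay. It differs from compound 2 in one place only: 4-methylphenyl in place of 2-methylphenyl on an oxygen on a saturated carbon. The most relevant comparison is the step from compound 1 to compound 2, because a 1.1-fold lower number from compound 1 to compound 2 (0.03 log units; within the scatter) shows that swapping one ring on that same oxygen left the number essentially unchanged. The change from compound 2 to compound 4 is of a similar kind, so no step beyond the scatter is expected in this assay; the expected step is a 1.0-fold lower number from compound 2 to compound 4 (0.02 log units; within the scatter). On that basis compound 4 is estimated at 52000 nM, with a likely range from 26000 nM to 104000 nM.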

Compound 4, half-maximal inhibitory concentration: 45700 nM
For compound 4 the middle estimate is 1.1-fold (0.06 log units) above the measured one; the measured number falls inside the stated range.
By their numbers in this assay, from the lowest: compounds 3, 4, 2 and 1 (each within the scatter of the next).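

In this assay, compound 2 and compound 4 carry the same atoms, and only the place of the methyl group differs, so this isolates that one feature in a way the earlier step on this oxygen, which also involved a chloro group, could not. The change gives a 1.2-fold lower number from compound 2 to compound 4 (0.08 log units; within the scatter), while 4-methylphenyl in place of 4-chloro-3-methylphenyl gives a 1.3-fold lower number from compound 1 to compound 4 (0.11 log units; within the scatter), so the assay does not separate these three rings on that oxygen. No measurement is available to explain this lack of separation.

Going by these compounds, the rings on that oxygen carry only methyl and chloro groups, so it remains open whether an amine, a carboxylic acid or a longer chain there would give a step beyond the scatter. On these data alone, it also remains open whether 4-methylphenyl would behave the same way with the bromo group of compound 3.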